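The source may report more compounds than this note shows. Statements on the series, on what has been measured and on what is new or still open speak of the compounds shown alone.

Measured in a functional assay on HepG2 cells (Homo sapiens) for antiproliferative activity, read by MTT assay, with a stated time of 72 h; on this read-out lower numbers stand for stronger inhibition and higher numbers for weaker inhibition:
- compound 1 `COc1cc2c(Nc3ccc(C#N)cc3)ncnc2cc1OCCCN1CCCC1`: 20900 nM
- compound 2 `COc1cc2c(Nc3ccc(C#N)cc3)ncnc2cc1OCCCN1CCCCC1`: 20700 nM
- compound 3 `COc1cc2c(Nc3ccc(C#N)cc3)ncnc2cc1OCCCN1CCC(CO)CC1`: 61800 nM

Compound 3 has the highest number of the three and is the weakest in this assay. The pyrrolidin-1-yl to piperidin-1-yl exchange makes no difference: a 1.0-fold lower number from compound 1 to compound 2 (0.00 log units; within the scatter). The two steps that lead to compound 3 are modest: a 3.0-fold higher number from compound 1 to compound 3 (0.47 log units; beyond the scatter) and a 3.0-fold higher number from compound 2 to compound 3 (0.48 log units; beyond the scatter).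

Next in the series is compound 4 `COc1cc2c(Nc3ccc(C#N)cc3)ncnc2cc1OCCCN1CCC(N(C)C)CC1`, not yet measured. The change is dimethylamino in place of hydroxymethyl on a saturated ring carbon, which puts dimethylamino in place of hydroxymethyl on a saturated ring carbon.

The closest evidence is the step that added the leaving hydroxymethyl, a 3.0-fold higher number from compound 2 to compound 3 (0.48 log units; beyond the scatter). For the measured compounds named here, the step of a 1.0-fold lower number from compound 1 to compound 2 (0.00 log units; within the scatter) suggests only that the unsubstituted ring exchange has little bearing. Going by the values given here, no measured compound carries dimethylamino, so its contribution is unknown. Losing hydroxymethyl may recover part of the modest rise seen at compound 3, which points to a lower number, with wide uncertainty. The expected change is a 2.1-fold lower number from compound 3 to compound 4 (0.31 log units; beyond the scatter). For compound 4 the estimate is 30000 nM, with an expected range of 10000 nM to 75000 nM.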

Compound 4, half-maximal inhibitory concentration: 33600 nM
The estimate for compound 4 lay 1.1-fold (0.05 log units) below the measured number; measured number inside the range.
By their numbers in this assay, from the lowest: compounds 2, 1, 4 and 3 (each within the scatter of the next, the first and the last beyond it).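

In this assay, dimethylamino and hydroxymethyl on this saturated ring carbon, three ring bonds from the ring nitrogen, are not separated (a 1.8-fold lower number from compound 3 to compound 4 (0.26 log units; within the scatter)), and the dimethylamino compound is also not separated from the rings without this substituent (a 1.6-fold higher number from compound 2 to compound 4 (0.21 log units; within the scatter)) and (a 1.6-fold higher number from compound 1 to compound 4 (0.21 log units; within the scatter)). The series now holds one substituent at this ring carbon that stays within the scatter of the unsubstituted piperidine and one that does not (a 3.0-fold higher number from compound 2 to compound 3 (0.48 log units; beyond the scatter)), so a substituent here does not by itself give a step beyond the scatter, although the gap between the two substituents also stays within it. Nothing measured beyond these antiproliferative numbers bears on the result, so no reason for it can be given.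

On these data alone, whether a primary amine or a carboxylic acid on the same ring carbon would stay with dimethylamino or give a step beyond the scatter remains open. Also open, as far as these compounds go, is whether a longer chain carrying 4-(dimethylamino)piperidin-1-yl, or a morpholine in place of the piperidine, would move the number on the shared core.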